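A few compounds are considered here, and "the series" means these few. Any claim that something is new, unique, unknown or untested is made for them only; others in the source may bear on it.

Compound 1 `O=C(/C=C/c1coc2cc(O)ccc2c1=O)NCc1ccc(F)cc1`: in a functional assay on A549 cells (Homo sapiens) for inhibition, read by MTT assay, with a stated time of 48 h (a lower number here means a stronger inhibitor, a higher number a weaker inhibitor), compound 1 reports only a limit, > 100000 nM.
Compound 2 `Cc1ccc(CNC(=O)/C=C/c2coc3cc(O)ccc3c2=O)cc1`: in this assay compound 2 gives 17400 nM.
Compound 3 `COc1ccc(CNC(=O)/C=C/c2coc3cc(O)ccc3c2=O)cc1`: in this assay compound 3 reports only a limit, > 100000 nM.

Within the data shown here, compound 2 therefore holds the only number in the set, the other two values being limits (the limit of > 100000 nM in this assay, at which 2 of the 3 values shown sit). Compound 4 `COc1ccc(NC(=O)/C=C/c2coc3cc(O)ccc3c2=O)cc1` is not yet measured. Its change from compound 2: 4-methoxyphenyl in place of 4-methylbenzyl on an amide-type nitrogen. The measured step that bears on it is an at least 5.7-fold higher number from compound 2 to compound 3 (0.75 log units; beyond the scatter), where methoxy replaced methyl on an aromatic carbon and the 4-methylbenzyl link otherwise stayed. Compound 4 carries methoxy as well, but as 4-methoxyphenyl set directly on the amide-type nitrogen, a shortening not tested here. A higher number than compound 2 is expected, on the scale of that step. Compound 4 is estimated at 70000 nM, range 25000 nM to 200000 nM. That means an expected 4.0-fold higher number from compound 2 to compound 4 (0.60 log units; beyond the scatter), with a real chance that only a limit is reported.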

Compound 4, half-maximal inhibitory concentration: 12800 nM
Beside the measured number, compound 4's estimate is 5.5-fold (0.74 log units) above it; the whole stated range lies above it.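

On the amide-type nitrogen, 4-methoxyphenyl in place of 4-methylbenzyl gives a 1.4-fold lower number from compound 2 to compound 4 (0.13 log units; within the scatter) in this assay, so the two cannot be told apart here. Compound 3, which also carries methoxy, reports only a limit, > 100000 nM. Compound 1 is likewise only a limit, and 4-methoxyphenyl in place of 4-fluorobenzyl gives an at least 7.8-fold lower number from compound 1 to compound 4 (0.89 log units; beyond the scatter), so methoxy is compatible with a measurable value when it arrives as 4-methoxyphenyl on this nitrogen.

Open, from the compounds shown here alone, is how a longer chain on the amide-type nitrogen, or an amine or carboxylic acid on the ring, would read. Comparisons within the series remain bounded by: the limit of > 100000 nM in this assay, at which 2 of the 4 values shown sit.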